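Compound 3 to compound 4: same atoms, rejoined side chain

The compounds below may be only part of what the source reports. "The series", "measured", "known", "first", "only" and "open" are said of these compounds alone.

In a functional assay on HeLa cells (Homo sapiens) for cytotoxicity, read by MTT assay, with a stated time of 48 h (on this read-out lower numbers stand for stronger inhibition and higher numbers for weaker inhibition), compound 1 `C=CC(C)(O)CC[C@@H]1C(=C)CC[C@H](Br)[C@@]1(C)CCC(Br)C(C)(C)O` has two entries (91800 nM; 47400 nM (2 entries)). Compound 2 `C=CC(C)(O)CC[C@@H]1C(=C)CC[C@H](Br)[C@@]1(C)CCC(OC)C(C)(C)O` reports only an assay limit (> 100000 nM). For the measured compounds named here, compound 3 `C=CC(C)(O)CC[C@@H]1C(=C)CC[C@H](Br)[C@@]1(C)CCC(=O)C(C)C` holds the only single number of the set (71400 nM). Going by the values given here, the one measured step (an at least 1.4-fold lower number from compound 2 to compound 3 (0.14 log units; that floor lies within the scatter)) is a floor because of the limit of > 100000 nM in this assay, at which 1 of the 3 values shown sits, and says little about size. Compound 4 `C=CC(C)(O)CC[C@@H]1C(=C)CC[C@H](Br)[C@@]1(C)CCC(O)C(=C)C` has the same atoms as compound 3, joined differently (1-hydroxy-2-methylprop-2-en-1-yl in place of isopropylcarbonyl on a saturated chain carbon, two bonds along the chain from a saturated ring carbon). Among the compounds with values here, no measured step covers this exchange, so with compound 3 at 71400 nM as anchor, no step beyond the scatter is expected in this assay (a 1.0-fold lower number from compound 3 to compound 4 (0.01 log units; within the scatter)). For compound 4 the estimate is 70000 nM (expected range 35000 nM to 100000 nM).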

Compound 4, half-maximal inhibitory concentration: > 100000 nM
Compound 4 was reported as a limit; the forecaster's own chance of this, stated with the estimate: 25%; middle value at least 1.4-fold (0.15 log units) from the limit.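

In this assay, 1-hydroxy-2-methylprop-2-en-1-yl in place of isopropylcarbonyl on this saturated chain carbon gives an at least 1.4-fold higher number from compound 3 to compound 4 (0.14 log units; that floor lies within the scatter), so rejoining the same atoms shows no lower number, and the printed floor lies within the scatter. From the compounds shown here alone, this step remains a floor, and its true size is unknown, because compound 4 is reported only as a limit: the limit of > 100000 nM in this assay, at which 2 of the 4 values shown sit. The step from compound 2 to compound 4 cannot be read. Still open, going by these compounds, is how far the number rises from compound 3 to compound 4, and whether an amine or a carboxylic acid at this position would shift the read-out beyond the scatter.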